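The source may report more compounds than this note shows. Statements on the series, on what has been measured and on what is new or still open speak of the compounds shown alone.

Measured compounds:
- Compound 1 `COc1ccc(S(=O)(=O)N(CC(N)=O)c2ccc(N(CC(N)=O)S(=O)(=O)c3ccc(NC(C)=O)cc3)c3ccccc23)cc1`: in a functional assay on cells (Peritoneal macrophage, Mus musculus) for cytotoxicity, with a stated time of 24 h (on this read-out higher numbers stand for lower toxicity in this test and lower numbers for higher toxicity in this test), compound 1 gives > 50000 nM, which is a limit of the assay, not a number.
- Compound 2 `CCC(=O)Nc1ccc(S(=O)(=O)N(CC(N)=O)c2ccc(N(CC(N)=O)S(=O)(=O)c3ccc(OC)cc3)c3ccccc23)cc1`: in this assay compound 2 gives > 50000 nM, again a limit.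
- Compound 3 `CCN1CCN(CC(=O)Nc2ccc(S(=O)(=O)N(CC(N)=O)c3ccc(N(CC(N)=O)S(=O)(=O)c4ccc(OC)cc4)c4ccccc34)cc2)CC1`: in this assay compound 3 gives > 100000 nM, also a limit.

Among the compounds with values here, compound 2 thus stands at a limit, and the two further values shown are limits as well; no compound has a read number. The unmeasured compound 4 `COc1ccc(S(=O)(=O)N(CC(N)=O)c2ccc(N(CC(N)=O)S(=O)(=O)c3ccc(NC(=O)CN4CCN(C(C)C)CC4)cc3)c3ccccc23)cc1` differs from compound 2 by 4-isopropylpiperazin-1-yl in place of methyl on a saturated chain carbon bound to a carbonyl carbon.

The closest measured step is a step that the two limits leave unreadable from compound 2 to compound 3, in which a 4-ethylpiperazin-1-yl replaces the same methyl. The other steps, a step that the two limits leave unreadable from compound 1 to compound 2 and a step that the two limits leave unreadable from compound 1 to compound 3, are likewise unreadable. What is known is only the limit of > 100000 nM in this assay, at which 1 of the 3 values shown sits, and (the limit of > 50000 nM in this assay, at which 2 of the 3 values shown sit); none of the three values sits inside the measured range, so no size or direction can be taken from them.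

For the step to compound 4 the expectation is therefore no change beyond the scatter, with the read-out most likely again a limit. Compound 4 is expected to give 100000 nM (range 50000 nM to 300000 nM). The expected step is a step that the limit leaves unreadable from compound 2 to compound 4.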

Compound 4, half-maximal cytotoxic concentration: > 100000 nM
Compound 4 ended at the assay's limit; the forecaster's own chance of this, stated with the estimate: 85%; the middle value sits exactly at the limit.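

In this assay, within the data shown here, compound 4 gives > 100000 nM, which is a limit of the assay and not a number, so no step linking compound 4 with compound 1, compound 2 or compound 3 can be read. The compounds shown leave open at which concentration any of them turns toxic in this assay, and whether 4-isopropylpiperazin-1-yl in place of methyl changes the read-out at all.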